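Dichlorophenyl for aminophenyl on the carbonyl

The source may hold more compounds than are shown below. What is called first, only, known or untested is meant among the compounds shown, and "the series" means these compounds.

Compound 1 `COc1ccc(-c2cc(/C=C/C(=O)c3ccc(N)cc3)[nH]n2)cc1` and compound 2 `COc1cc(-c2cc(/C=C/C(=O)c3ccc(N)cc3)[nH]n2)cc(OC)c1OC` share a core and differ only in the substitution of the aryl ring attached to it. In a functional assay on HT-29 cells (Homo sapiens) for inhibition, read by sulforhodamine B assay, with a stated time of 48 h (on this read-out lower numbers stand for stronger inhibition of growth and higher numbers for weaker inhibition of growth), compound 1 gives 8110 nM. In this assay compound 2 gives 4820 nM, and the two numbers sit within the scatter of each other, so compound 2 stands level with compound 1. Compound 3 `COc1cc(-c2cc(/C=C/C(=O)c3ccc(Cl)c(Cl)c3)[nH]n2)cc(OC)c1OC` carries 3,4-dichlorophenyl in place of 4-aminophenyl on a carbonyl carbon. For the measured compounds named here, no measured pair for this replacement exists, so the size of the move is open. A moderate step toward stronger inhibition of growth is expected, a 1.6-fold lower number from compound 2 to compound 3 (0.21 log units; within the scatter). Compound 3 is estimated at 3000 nM, with a range from 800 nM to 12000 nM.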

Compound 3, concentration for total growth inhibition: > 100000 nM
Compound 3 ended at the assay's limit; the forecaster's own chance of this, stated with the estimate: 5%; middle value at least 33-fold (1.52 log units) from the limit.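

On this carbonyl carbon, the group matters far more than the aryl change between compound 1 and compound 2, whose values sit within the scatter of each other. In this assay, 3,4-dichlorophenyl in place of 4-aminophenyl gives an at least 20-fold higher number from compound 2 to compound 3 (1.31 log units; beyond the scatter). The value of compound 3 is a limit and not a number, so the full size of this step remains unknown: the limit of > 100000 nM in this assay, at which 1 of the 3 values shown sits.

The step does not separate loss of the amino group from gain of the two chlorine atoms. From the compounds shown here alone, a plain phenyl group at this position would help to separate them, and whether the same swap behaves alike on compound 1 remains open.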